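A Small Swap: Bromo Gives Way to Methyl

This account rests on a few compounds, and the source may have more. Where it says the series, first, only, none or still open, it means among the compounds named here.

In a functional assay on HepG2 cells (Homo sapiens) for antiproliferative activity, read by colorimetric assay and MTT assay, with a stated time of 48 h (a higher number here means a weaker inhibitor, a lower number a stronger inhibitor), compound 2 `O=C(NS(=O)(=O)c1ccc(Br)cc1)c1ccncc1` gives 6300 nM and compound 1 `O=C(NS(=O)(=O)c1ccc(F)cc1)c1ccncc1` gives 12400 nM, so these two values lie within the scatter of each other. Compound 3 `Cc1ccc(S(=O)(=O)NC(=O)c2ccncc2)cc1` has methyl in place of bromo on an aromatic carbon. Among the compounds with values here, the only measured step that bears on this change is a 2.0-fold lower number from compound 1 to compound 2 (0.29 log units; within the scatter), with bromo in place of fluoro on an aromatic carbon, and it stays within the scatter. No step beyond the scatter is therefore expected in this assay. The estimated step is a 1.3-fold higher number from compound 2 to compound 3 (0.10 log units; within the scatter). Compound 3 is expected at 8000 nM, within an estimated range of 3500 nM to 18000 nM.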

Compound 3, half-maximal inhibitory concentration: 20200 nM
Estimate against measurement, compound 3: 2.5-fold (0.40 log units) below, and the stated range ends below it.
By their numbers in this assay, from the lowest: compounds 2, 1 and 3 (each within the scatter of the next, the first and the last beyond it).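

Methyl in place of bromo on this aromatic carbon gives a 3.2-fold higher number from compound 2 to compound 3 (0.51 log units; beyond the scatter) in this assay and is the first step here to pass the scatter, so a swap at this place can shift the number measurably. Methyl in place of fluoro gives a 1.6-fold higher number from compound 1 to compound 3 (0.21 log units; within the scatter) and so does not separate those two compounds; only compound 2 and compound 3 stand apart. No measurement here accounts for that gap.

On these data alone, whether an amine, a carboxylic acid or a longer chain at this place would lower the number or raise it remains open.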